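The source may hold more compounds than are shown below. What is called first, only, known or untested is meant among the compounds shown, and "the series" means these compounds.

Compound 1 `COc1ccc2c(c1)c(CC(=O)OCOC(=O)C(C)(C)C)c(C)n2C(=O)c1ccc(Cl)cc1` gives 4.6 in a physicochemical assay for lipophilicity, read by HPLC, measured as octanol-water partition, at pH 3; a higher number here means a more lipophilic compound, a lower number a more polar compound.
Compound 2 `COc1ccc2c(c1)c(CC(=O)OCOC(=O)OC(C)C)c(C)n2C(=O)c1ccc(Cl)cc1` gives 5.1 in this assay.
Compound 3 `COc1ccc2c(c1)c(CC(=O)OCCOC(C)=O)c(C)n2C(=O)c1ccc(Cl)cc1` gives 4.2 in this assay.

Compound 3 stands lowest of the three; the nearest is compound 1, reached by a number 0.40 log units lower from compound 1 to compound 3 (beyond the scatter), and the furthest is compound 2, reached by a number 0.90 log units lower from compound 2 to compound 3 (beyond the scatter). Compound 4 `COc1ccc2c(c1)c(CC(=O)OCc1oc(=O)oc1C)c(C)n2C(=O)c1ccc(Cl)cc1` differs from compound 3 in one place: a group of 7 heavy atoms (4 carbon, 3 oxygen; one five-membered aromatic ring with 2 hetero atoms) in place of a group of 5 heavy atoms (3 carbon, 2 oxygen; no ring), on a saturated chain carbon bound to an oxygen next to a carbonyl group. Within the data shown here, the steps that bear on this are those at the same position, a number 0.40 log units lower from compound 1 to compound 3 (beyond the scatter) and a number 0.90 log units lower from compound 2 to compound 3 (beyond the scatter), both modest; the ester-to-carbonate step a number 0.50 log units higher from compound 1 to compound 2 (beyond the scatter) was also modest. Among the measured compounds shown here, none of them carries a ring, so the new group has no direct precedent here. He expects a small step, a number 0.10 log units higher from compound 3 to compound 4 (within the scatter), likely within the scatter. His estimate for compound 4 in this assay is 4.3, between 3.9 and 4.7.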

Compound 4, partition coefficient: 4.5
Beside the measured number, compound 4's estimate is 0.20 log units below it; measured number inside the range.
By their numbers in this assay, from the lowest: compounds 3, 4 and 1 (each within the scatter of the next, the first and the last beyond it); then compound 2.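

At this position, on a saturated chain carbon bound to an oxygen next to a carbonyl group, a group with a five-membered aromatic ring gives no step beyond the scatter from either of two ring-free groups in this assay: a number 0.30 log units higher from compound 3 to compound 4 (within the scatter) and a number 0.10 log units lower from compound 1 to compound 4 (within the scatter). A ring-free group with the same 4 carbon and 3 oxygen atoms does stand apart, with a number 0.60 log units lower from compound 2 to compound 4 (beyond the scatter), so the heavy-atom count alone does not fix the number in this series. Nothing shown here accounts for these differences.

The compounds shown leave open whether the methyl on the ring matters, and what a longer chain on that ring would give. They also leave open how a morpholine or another amine on the saturated chain carbon would compare.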